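The source may report more compounds than this note shows. Statements on the series, on what has been measured and on what is new or still open speak of the compounds shown alone.

Measured so far in an ADME assay on CHO cells (Cricetulus griseus) for inhibition, read by MTT assay; on this read-out higher numbers stand for weaker inhibition and lower numbers for stronger inhibition:
- compound 1 `CCN(CC)Cc1cc(C)cc(Nc2nc3ccccc3n2Cc2ccc(F)cc2)c1O`: 18700 nM
- compound 2 `CCN(CC)Cc1cc(F)cc(Nc2nc3ccccc3n2Cc2ccc(C(F)(F)F)cc2)c1O`: > 50000 nM

Compound 2 has no number in this assay, and its entry > 50000 nM is a limit of the assay. It sits at the limit of > 50000 nM in this assay, at which 1 of the 2 values shown sits.

The next compound is compound 3 `CCN(CC)Cc1cc(C)cc(Nc2nc3ccccc3n2Cc2ccc(C(F)(F)F)cc2)c1O`, still to be measured. It is reached from compound 2 by putting methyl in place of fluoro on an aromatic carbon, para to a hydroxy group: methyl in place of fluoro on an aromatic carbon.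

Among the compounds with values here, no pair of measured compounds differs in one place only, so the series offers no direct measure of this change. Within the data shown here, the only guide is compound 1, which also carries methyl at that carbon and reads 18700 nM. On that basis, a moderate move towards stronger inhibition in this assay is expected, with a real chance that compound 3 also ends at the limit. The estimate means an at least 1.6-fold lower number from compound 2 to compound 3 (0.22 log units; that floor lies within the scatter), an expected step whose starting point is only a limit.

For compound 3 the expected value is 30000 nM, with an estimated range of 13000 nM to 60000 nM.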

Compound 3, half-maximal inhibitory concentration: 29300 nM
Compound 3: the middle estimate sits 1.0-fold (0.01 log units) above what was measured; measured number inside the range.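

In this assay compound 2 stands only at a limit and has no number: the limit of > 50000 nM in this assay, at which 1 of the 3 values shown sits. With the trifluoromethyl group held constant, methyl in place of fluoro on the aromatic carbon para to a hydroxy group gives an at least 1.7-fold lower number from compound 2 to compound 3 (0.23 log units; that floor lies within the scatter), so this change brings the read-out off the limit, although its size remains a floor and that floor does not clear the usual scatter. With methyl held at that carbon, trifluoromethyl in place of fluoro on the other aromatic carbon gives a 1.6-fold higher number from compound 1 to compound 3 (0.20 log units; within the scatter), so this second exchange is not resolved on this read-out.

The compounds shown leave open how a chlorine atom, a methoxy group or an amine would read at the carbon para to the hydroxy group, since methyl and fluoro are the only groups shown there. From the compounds shown here alone, it also remains open whether methyl in place of fluoro at that carbon gives a similar step when fluoro rather than trifluoromethyl sits on the other aromatic carbon, and a true size for the step needs a number in place of a limit.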